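Amide variation on the shared core

The source may hold more compounds than are shown below. What is called first, only, known or untested is meant among the compounds shown, and "the series" means these compounds.

Compound 1 `O=C(O)c1nc(N2CCN(C(=O)COc3ccc(Cl)cc3)CC2)c2cc(F)sc2n1` gives > 10000 nM in a functional assay on cells (Lymphocyte) (a lower number here means a stronger inhibitor, a higher number a weaker inhibitor), a limit of the assay.
Compound 2 `Nc1nc(N2CCN(C(=O)COc3ccc(Cl)cc3)CC2)c2cc(F)sc2n1` gives 700 nM in this assay.

Compound 2 holds the only number shown; the other value is a limit. For the measured compounds named here, the one measured step, an at least 14-fold lower number from compound 1 to compound 2 (1.15 log units; beyond the scatter), concerns the amino in place of carboxy on an aromatic carbon and leaves the amide end untouched. Compound 3 `Cc1cccc(NC(=O)N2CCN(c3nc(N)nc4sc(F)cc34)CC2)c1` differs from compound 2 by (3-methylphenyl)amino in place of (4-chlorophenoxy)methyl on a carbonyl carbon. Going by the values given here, no measured step bears on this change, so in this assay no step beyond the scatter is assumed, with a wide range. Compound 3 is expected at 700 nM (150 nM to 3500 nM), that is no change at the digits printed from compound 2 to compound 3 (within the scatter).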

Compound 3, half-maximal inhibitory concentration: 2800 nM
Estimate against measurement, compound 3: 4.0-fold (0.60 log units) below; the measured number falls inside the stated range.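

The amide end of the shared core is sensitive to substitution: the change on the carbonyl carbon gives a 4.0-fold higher number from compound 2 to compound 3 (0.60 log units; beyond the scatter) in this assay, with the amino group of compound 2 held constant. The step changes the ring substituent and the link to the carbonyl together, so it cannot assign the loss to either one. Nothing measured here gives a reason for this step.

Still open, going by these compounds, is how (4-chlorophenyl)amino or phenoxymethyl on the carbonyl carbon would read in this assay. Either group would separate the ring substituent from the link.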